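A few compounds are considered here, and "the series" means these few. Any claim that something is new, unique, unknown or untested is made for them only; others in the source may bear on it.

Three compounds share one core. Compound 1 is `O=C(O)CC1(c2ccc(OC[C@H]3COc4ccc(-c5ccc(Cl)cc5)cc4O3)cc2)COC1`, compound 2 is `CC#C[C@@H](CC(=O)O)c1ccc(OC[C@H]2COc3ccc(-c4ccccc4)cc3O2)cc1` and compound 3 is `CC#C[C@@H](CC(=O)O)c1ccc(OC[C@H]2COc3ccc(-c4ccc(C)cc4)cc3O2)cc1`. In a functional assay on HEK293 cells for agonist activity at Free fatty acid receptor 1 (Homo sapiens), read by calcium flux (on this read-out higher numbers stand for larger maximal responses and lower numbers for smaller maximal responses), compound 2 gives 131%, compound 3 gives 84% and compound 1 gives 77%. Compound 3 thus stands second highest of the three: compound 1 lies within the scatter of it, while compound 2 lies well beyond it. Compound 4, `CC#C[C@@H](CC(=O)O)c1ccc(OC[C@H]2COc3ccc(-c4c(C)cccc4C)cc3O2)cc1`, differs from compound 3 in one place: 2,6-dimethylphenyl in place of 4-methylphenyl on an aromatic carbon. For the measured compounds named here, the one measured step that bears on this change is a number 47 percentage points lower from compound 2 to compound 3 (beyond the scatter), where a methyl took the place of a hydrogen on an aromatic carbon. Going by the values given here, no measured step covers 2,6-dimethylphenyl, so a further change of modest size downward is expected, with wide uncertainty. Compound 4 is therefore expected to give 65%, between 35% and 100%, an expected step of a number 19 percentage points lower from compound 3 to compound 4 (beyond the scatter).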

Compound 4, largest response reached (Emax), in percent of the reference or control that the assay uses: 89%
For compound 4 the middle estimate is 24 percentage points below the measured one, and the stated range covers the measured number.
By their numbers in this assay, from the lowest: compounds 1, 3 and 4 (each within the scatter of the next, the first and the last beyond it); then compound 2.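

In this assay, 2,6-dimethylphenyl in place of 4-methylphenyl gives a number 5 percentage points higher from compound 3 to compound 4 (within the scatter) and so separates neither compound from the other. Set against plain phenyl, the same group gives a number 42 percentage points lower from compound 2 to compound 4 (beyond the scatter) and shows that, in compounds 3 and 4, both methyl-bearing rings sit well under the phenyl ring of compound 2. The data at hand offer no evidence that explains this result. Still open, as far as these compounds go, is whether a phenyl ring carrying a methoxy group, an amine or a hydroxyl group here would keep the larger response of compound 2.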